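Adding a Sulfamoyl Group to Compound 1

The source may report more compounds than this note shows. Statements on the series, on what has been measured and on what is new or still open speak of the compounds shown alone.

Compound 1 (`CCSC(=S)SCC(=O)c1ccccc1`) serves as the reference point in this small series. In a functional assay on HeLa cells (Homo sapiens) for antiproliferative activity, read by resazurin assay (a lower number here means a stronger inhibitor, a higher number a weaker inhibitor), compound 1 gives 5010 nM. Compound 3 (`CCSC(=S)SCC(=O)c1cccc(OC)c1`) gives 5010 nM, level with compound 1 at the digits reported, and compound 2 (`CCSC(=S)SCC(=O)c1ccccc1C`) gives 10000 nM. The gap from compound 1 to compound 2 stays within the scatter.

Compound 4 (`CCSC(=S)SCC(=O)c1ccc(S(N)(=O)=O)cc1`) keeps the core of compound 1 and differs in one place: sulfamoyl in place of hydrogen on an aromatic carbon.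

Going by the values given here, two measured steps bear on this change, since each also replaces hydrogen on an aromatic carbon. Methyl gives a 2.0-fold higher number from compound 1 to compound 2 (0.30 log units; within the scatter), and methoxy gives no change at the digits printed from compound 1 to compound 3 (within the scatter). Neither step moved the number beyond the scatter. However, neither involves a sulfamoyl group, and neither substituent stands para to a group of 9 heavy atoms, so the guidance they offer is limited.

No step beyond the scatter is therefore expected in this assay, and no direction is favoured with any confidence. The estimated result is a 1.2-fold higher number from compound 1 to compound 4 (0.08 log units; within the scatter). For compound 4 the expected value is 6000 nM, with an estimated range from 2000 nM to 20000 nM.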

Compound 4, half-maximal inhibitory concentration: 20000 nM
For compound 4 the middle estimate is 3.3-fold (0.52 log units) below the measured one, and the stated range covers the measured number.
By their numbers in this assay, from the lowest: compounds 1, 3, 2 and 4 (each within the scatter of the next, the first and the last beyond it).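

In this assay, going by these compounds alone, sulfamoyl in place of hydrogen on an aromatic carbon gives a 4.0-fold higher number from compound 1 to compound 4 (0.60 log units; beyond the scatter) and so makes compound 4 a weaker inhibitor than compound 1, a modest step but the only one measured from compound 1 that lies beyond the scatter. Within the data shown here, the methyl and methoxy steps had stayed within the scatter, so this is the first sign that the number responds to a substitution on this aromatic ring, here on the carbon para to the group of 9 heavy atoms. No evidence at hand explains the shift, and the direction and size of this one step are all that can be stated.

The compounds shown do not separate the effect of the sulfamoyl group from that of its place, as no other group stands on this carbon and sulfamoyl stands on no other carbon of the ring. From the compounds shown here alone, it remains open whether methyl, methoxy, an amine or a carboxylic acid on this same carbon would raise the number as well, or whether the step belongs to sulfamoyl alone.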